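Chloro for methyl on the shared core of compound 1

The compounds below may be only part of what the source reports. "The series", "measured", "known", "first", "only" and "open" are said of these compounds alone.

Measured compounds in an assay on isolated protein for inhibition of tyrosine-protein kinase receptor UFO (Homo sapiens), read by TR-FRET, with a stated time of 60 min; a lower number here means a stronger inhibitor, a higher number a weaker inhibitor:
compound 1 `Cc1cnc(Nc2ccc(CN3CCN(C)CC3)cc2)nc1-c1ccc(F)cc1S(=O)(=O)N1CCCC1`: 2930 nM
compound 2 `CN1CCN(Cc2ccc(Nc3ncc(Cl)c(Nc4ccc(F)cc4S(=O)(=O)N4CCOCC4)n3)cc2)CC1`: 240 nM
compound 3 `CN1CCN(Cc2ccc(Nc3ncc(Cl)c(Nc4ccc(F)cc4S(=O)(=O)N4CCCC4)n3)cc2)CC1`: 37 nM

Compound 1 stands highest of the three numbers in this assay; compound 2 is nearest and compound 3 furthest, both gaps beyond the scatter. Going by the values given here, the one step that can be read within the set is a 6.5-fold lower number from compound 2 to compound 3 (0.81 log units; beyond the scatter), and it concerns the group on the sulfonyl sulfur, not the ring carbon changed here.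

Compound 4 `CN1CCN(Cc2ccc(Nc3ncc(Cl)c(-c4ccc(F)cc4S(=O)(=O)N4CCCC4)n3)cc2)CC1` is not yet measured. It differs from compound 1 by chloro in place of methyl on an aromatic carbon. Among the compounds with values here, no measured pair isolates this swap: compound 1 and compound 3 differ in more than one place, so their values cannot be split into parts. What the numbers show is that the two chloro compounds, compound 2 and compound 3, sit well below compound 1, with the pyrrolidin-1-yl compound 3 lowest.

The change exchanges one heavy atom for one heavy atom, with no change in ring count, donors, acceptors or charge. Within the data shown here, the expectation is a step downward, a 4.2-fold lower number from compound 1 to compound 4 (0.62 log units; beyond the scatter), modest and with a wide range since no direct precedent exists. Compound 4 is estimated at 700 nM, between 150 nM and 3000 nM.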

Compound 4, half-maximal inhibitory concentration: 91 nM
For compound 4 the middle estimate is 7.7-fold (0.89 log units) above the measured one; the measured number lies below the stated range.
By their numbers in this assay, from the lowest: compound 3; then compound 4; then compound 2; then compound 1.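

In this assay chloro in place of methyl on this aromatic carbon gives a 32-fold lower number from compound 1 to compound 4 (1.51 log units; beyond the scatter) as a single change, so this position, ortho to a large group and two atoms from the ring nitrogen, matters on its own, with one heavy atom leaving, one entering, and no change in counted donors, acceptors or charge. Going by these compounds alone, the earlier compounds could not isolate this swap: their only readable step, a 6.5-fold lower number from compound 2 to compound 3 (0.81 log units; beyond the scatter), lay on the sulfonyl sulfur and is modest against this large one. No measured evidence bearing on the cause of the step is available.

Among the compounds shown, only chloro and methyl can be compared at this carbon, so bromo, fluoro or a nitrile there remains open, as does whether the step holds with morpholin-4-yl on the sulfonyl sulfur. Compound 3 at 37 nM and compound 4 at 91 nM differ in the link to the fluorinated ring, an amine nitrogen against a direct bond, which leaves an ether oxygen or a methylene link open.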